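A few compounds are considered here, and "the series" means these few. Any claim that something is new, unique, unknown or untested is made for them only; others in the source may bear on it.

Three compounds sharing a chromenone-type core, here simply called the shared core, have been tested so far in a functional assay on SK-HEP1 cells (Homo sapiens) for antiproliferative activity; a higher number here means a weaker inhibitor of growth, a lower number a stronger inhibitor of growth. Compound 1 `C/C(COc1ccc2c(=O)cc(-c3ccccc3)oc2c1)=N\O` gives 2800000 nM in this assay. Compound 2 `CO/N=C(\C)COc1ccc2c(=O)cc(-c3ccccc3)oc2c1` gives 2000000 nM, and the step of a 1.4-fold lower number from compound 1 to compound 2 (0.15 log units; within the scatter) stays within the scatter. Compound 3 `O=c1c(OC/C(=N/O)c2ccccc2)c(-c2ccccc2)oc2ccccc12` gives 7210000 nM, the highest of the three numbers; compound 1 is nearest to it, and compound 2 furthest, both lower by amounts beyond the scatter, so compound 3 is the weakest inhibitor of growth among the measured set.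

Compound 4 `O=c1c(OC/C(=N/O)c2ccc(F)cc2)c(-c2ccccc2)oc2ccccc12` is not yet measured. It differs from compound 3 in one place: fluoro in place of hydrogen on an aromatic carbon. Among the measured compounds shown here, no measured step bears on this change; the single step that exists concerns a methyl entering on an oxygen in a different part of the molecule and lies within the scatter, so nothing in the data points to a direction for a fluoro entering an aromatic ring. The expected step from compound 3 to compound 4 is therefore a 1.0-fold lower number from compound 3 to compound 4 (0.01 log units; within the scatter), none beyond the scatter. On that basis compound 4 is estimated to give 7000000 nM in this assay, with a range from 3000000 nM to 16000000 nM.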

Compound 4, concentration for 50% growth inhibition: 6900000 nM
Compound 4: middle estimate off by 1.0-fold (0.01 log units), on the high side; measured number inside the range.
By their numbers in this assay, from the lowest: compounds 2 and 1 (each within the scatter of the next); then compounds 4 and 3 (each within the scatter of the next).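

Among the compounds shown here, the step of a 1.0-fold lower number from compound 3 to compound 4 (0.02 log units; within the scatter) in this assay is the first reading of any change on this aromatic ring, since the only earlier step concerned a methyl on an oxygen elsewhere in the molecule. It shows that going from phenyl to 4-fluorophenyl, with one fluorine atom entering para to a large group, leaves compound 3 and compound 4 within the scatter of each other, so at this place on the ring hydrogen and fluoro cannot be told apart by their numbers in this assay. No measured information on the fluoro group or on this ring accompanies the result, which therefore stands as an observation without an explanation.

On these data alone, a single atom at a single place says little about the place as a whole, and it remains open whether a larger or differently built group there, such as a methoxy, an amine or a carboxylic acid, would move the number beyond the scatter. As far as these compounds go, it also remains open whether fluoro on another carbon of this ring, or on the other phenyl, would give the same flat reading.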